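A ring change on the shortest-lived compound

The source may report more compounds than this note shows. Statements on the series, on what has been measured and on what is new or still open speak of the compounds shown alone.

For the measured compounds named here, in an in vitro ADME assay on microsomes from liver (Homo sapiens) for metabolic stability (on this read-out higher numbers stand for a longer-lived compound and lower numbers for a shorter-lived compound), compound 1 `CS(=O)(=O)Nc1ccc2c(c1)S(=O)(=O)N=C(C1=C(O)C3CCCC3N(CCC3CC3)C1=O)N2` gives 0.417 h, the only exact number among the measured compounds. Compound 2 `CS(=O)(=O)Nc1ccc2c(c1)S(=O)(=O)N=C(C1=C(O)C3CCCCCCC3N(Cc3ccc(F)cc3)C1=O)N2` reads > 1 h, which is a limit of the assay. Compound 3 `CS(=O)(=O)Nc1ccc2c(c1)S(=O)(=O)N=C(C1=C(O)[C@H]3CCC[C@H]3N(Cc3ccc(F)c(F)c3)C1=O)N2` reads > 1 h, which is also a limit. Compound 4 `CS(=O)(=O)Nc1ccc2c(c1)S(=O)(=O)N=C(C1=C(O)C3CCCC3N(CC3CCC3)C1=O)N2` has not yet been measured. It differs from compound 1 by cyclobutyl in place of cyclopropylmethyl on a saturated chain carbon bound to an amide-type nitrogen in a ring, with cyclobutyl in place of cyclopropylmethyl on a saturated chain carbon bound to an amide-type nitrogen in a ring. Going by the values given here, no measured pair shows this change, so no shift beyond the scatter is expected in this assay. The expected change is a 1.1-fold higher number from compound 1 to compound 4 (0.03 log units; within the scatter). For compound 4 the estimated half-life is 0.45 h, with an expected range of 0.22 h to 0.9 h.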

Compound 4, half-life: 0.0667 h
Compound 4: middle estimate off by 6.7-fold (0.83 log units), on the high side; the measured number lies below the stated range.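

In this assay the change to cyclobutyl in place of cyclopropylmethyl on a saturated chain carbon bound to an amide-type nitrogen in a ring gives a 6.3-fold lower number from compound 1 to compound 4 (0.80 log units; beyond the scatter) with the heavy atom and hydrogen-bond counts unchanged. For the compounds shown here, this position therefore responds to how the same four carbons are joined, which the earlier compounds did not show. From the compounds shown here alone, whether cyclopentyl or a longer chain such as n-butyl there would give a longer or shorter half-life stays open. Compound 2 and compound 3 offer no comparison, since they differ from compound 1 in more than one place and read as limits: the limit of > 1 h in this assay, at which 2 of the 4 values shown sit.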